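A few compounds are considered here, and "the series" means these few. Any claim that something is new, unique, unknown or untested is made for them only; others in the source may bear on it.

Among the compounds with values here, in a functional assay on KB cells (Homo sapiens) for cytotoxicity, read by sulforhodamine B assay, with a stated time of 3 days (a higher number here means that more compound is needed for the effect, a lower number that less compound is needed), only two compounds have been read so far. Compound 1 `CCOCc1c(C)coc1-c1ccc2c(c1OC)CCCC2(C)C` gives 21.6 uM and compound 2 `Cc1coc(-c2ccc3c(c2O)CCCC3)c1C(=O)O` gives 50 uM. Compound 1 therefore stands lowest of the two, by a gap beyond the usual scatter. The pair differs in more than one place, so it isolates no single change. Compound 3 `COC(=O)c1c(C)coc1-c1ccc2c(c1OC)CCCC2(C)C` keeps the core of compound 1 and carries methoxycarbonyl in place of ethoxymethyl on an aromatic carbon, two ring bonds from the ring oxygen: methoxycarbonyl in place of ethoxymethyl on an aromatic carbon. Within the data shown here, no measured pair covers this exchange, so the expectation is a loose one. Among the measured compounds shown here, the only guide is that compound 2, at 50 uM, lies above compound 1, and the new group is of equal heavy-atom count. A small rise in this assay is expected, one that may hardly clear the scatter. The estimated change is a 1.5-fold higher number from compound 1 to compound 3 (0.17 log units; within the scatter). For compound 3 the expected value is 32 uM, with an estimated range of 13 uM to 70 uM.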

Compound 3, concentration for half-maximal effect: 53.4 uM
Compound 3: middle estimate off by 1.7-fold (0.22 log units), on the low side; measured number inside the range.
By their numbers in this assay, from the lowest: compound 1; then compounds 2 and 3 (each within the scatter of the next).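

In this assay, within the data shown here, the exchange of ethoxymethyl for methoxycarbonyl on this aromatic carbon, two ring bonds from the ring oxygen, gives a 2.5-fold higher number from compound 1 to compound 3 (0.39 log units; beyond the scatter), the first step that isolates a single place. The two groups have the same count of 4 heavy atoms, so the step arises from an exchange that leaves that count unchanged, while methoxycarbonyl brings a double bond outside aromatic rings and 2 hydrogen-bond acceptors against 1 for ethoxymethyl. No measurement at hand bears on which of these differences lies behind the step, so it stands as an observation about this one pair.

As far as these compounds go, it remains open how other groups, such as hydroxymethyl, a primary amide or an aminomethyl group, would read at this place on the core of compound 1, and whether any of them would give a lower number than compound 1, which gives 21.6 uM. From the compounds shown here alone, it is also open whether the same exchange would give a step of similar size on a different core.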